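The source may report more compounds than this note shows. Statements on the series, on what has been measured and on what is new or still open speak of the compounds shown alone.

Compound 2 is `COc1cc(Nc2n[nH]c(-c3cccnc3Oc3cc(OC)cc(OC)c3)n2)cc(OC)c1`. In a functional assay on A-431 cells (Homo sapiens), tested at 0.1 uM (a higher number here means more inhibition at the concentration tested (going by the name of the read-out), a lower number less inhibition), compound 2 gives 87%. For the measured compounds named here, this is the only number the series has so far: for compound 1, `COc1cc(Nc2n[nH]c(-c3cccnc3Nc3cc(OC)cc(OC)c3)n2)cc(OC)c1`, the entry in this assay reads "not determined" (no result reported), so it carries no result. Going by the values given here, compound 2 is therefore the sole point of reference, and no step between two measured compounds exists to show how much a change at this position moves the read-out.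

Compound 3, `COc1ccc(CNc2n[nH]c(-c3cccnc3Oc3cc(OC)cc(OC)c3)n2)cc1`, is not yet measured. It differs from compound 2 in one place: 4-methoxybenzyl in place of 3,5-dimethoxyphenyl on a nitrogen on an aromatic ring. Among the compounds with values here, the single value available gives no calibration for a change of this kind, so the expectation rests on the measurement of compound 2 alone. The step of a number 32 percentage points lower from compound 2 to compound 3 (beyond the scatter) that the estimate implies is expected to be downward and somewhat larger than the usual scatter. Compound 3 is estimated at 55% in this assay, with a range from 20% to 85%.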

Compound 3, a percentage reported as inhibition, at one concentration (the size of the read-out at that concentration, not a potency): 28%
Compound 3: the middle estimate sits 27 percentage points above what was measured, within the range that was stated.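

In this assay, the series now has its first readable step: 4-methoxybenzyl in place of 3,5-dimethoxyphenyl on a nitrogen on an aromatic ring gives a number 59 percentage points lower from compound 2 to compound 3 (beyond the scatter), so the read-out is sensitive to the group at this position, at least for this pair. The change alters both the ring attachment, benzyl for phenyl, and the methoxy pattern, and this single step cannot separate the two. No measured evidence on the compounds accounts for the size of the step.

A 3,5-dimethoxybenzyl group would keep the methoxy pattern of compound 2 on a benzyl, while a 4-methoxyphenyl group would keep the phenyl attachment with the methoxy pattern of compound 3, and neither is among the compounds shown. Going by these compounds, how a morpholine or a carboxylic acid at this nitrogen would read also remains open.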